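Methyl Position Swap on a Benzisoselenazolone Thiadiazole

The source may hold more compounds than are shown below. What is called first, only, known or untested is meant among the compounds shown, and "the series" means these compounds.

Compound 1 `O=c1c2ccccc2[se]n1-c1nnc(-c2ccc(Br)cc2)s1`: 68200 nM
Compound 2 `Cc1cccc(-c2nnc(-n3[se]c4ccccc4c3=O)s2)c1`: 17800 nM

Compound 1 carries a 4-bromophenyl on the thiadiazole carbon; in a functional assay on SSMC-7721 cells (Homo sapiens) for antiproliferative activity, read by CCK-8 assay, with a stated time of 48 h (on this read-out higher numbers stand for weaker inhibition and lower numbers for stronger inhibition), compound 1 gives 68200 nM. Compound 2 carries a 3-methylphenyl at the same carbon, and in this assay compound 2 gives 17800 nM. Among the measured compounds shown here, the single measured step, a 3.8-fold lower number from compound 1 to compound 2 (0.58 log units; beyond the scatter), is modest and beyond the scatter, and it leaves compound 2 with the lowest number of the two.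

Compound 3 `Cc1ccc(-c2nnc(-n3[se]c4ccccc4c3=O)s2)cc1` differs from compound 2 only in the position of the methyl group: 4-methylphenyl in place of 3-methylphenyl on an aromatic carbon. For the measured compounds named here, no measured step bears on moving a methyl around the phenyl ring; the one step at hand changes the substituent itself, not its position. Without a guiding step, the change from compound 2 to compound 3 is expected to stay within the scatter, a 1.0-fold higher number from compound 2 to compound 3 (0.00 log units; within the scatter). Compound 3 is therefore estimated at 18000 nM, with a range of 7000 nM to 45000 nM.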

Compound 3, half-maximal inhibitory concentration: 16600 nM
Compound 3: middle estimate off by 1.1-fold (0.04 log units), on the high side; the range from low to high includes it.
By their numbers in this assay, from the lowest: compounds 3 and 2 (each within the scatter of the next); then compound 1.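

In this assay, the move of the methyl around the phenyl ring gives a 1.1-fold lower number from compound 2 to compound 3 (0.03 log units; within the scatter), so 4-methylphenyl and 3-methylphenyl on this aromatic carbon cannot be told apart, and the position of the methyl on the phenyl ring shows no measurable effect here. Among the compounds shown here, the second new step, a 4.1-fold lower number from compound 1 to compound 3 (0.61 log units; beyond the scatter), is the first to change the group alone, with methyl in place of bromo at the same position of the phenyl ring, and it is beyond the scatter, much like the earlier step that changed both group and position. Nothing available accounts for either step.

On these data alone, whether bromo would read the same at the position of the methyl in compound 2 stays open. So does whether an amine, a carboxylic acid or a longer chain on the phenyl ring would move the number further than methyl does.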